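Working notes: from compound 3 to compound 4

The source may hold more compounds than are shown below. What is called first, only, known or untested is meant among the compounds shown, and "the series" means these compounds.

In a functional assay on HepG2 cells (Homo sapiens) for cytotoxicity, read by MTT assay, with a stated time of 72 h (on this read-out lower numbers stand for stronger inhibition and higher numbers for weaker inhibition), compound 1 `O=C(N/N=C/c1ccc(F)cc1)Nc1cc2c(Nc3ccc(F)c(Cl)c3)ncnc2cc1O[C@H]1CCOC1` gives "not active" (no number reported), so it offers no number to work from. Compound 2 `O=C(N/N=C/c1cccc(Br)c1)Nc1cc2c(Nc3ccc(F)c(Cl)c3)ncnc2cc1O[C@H]1CCOC1` gives 32300 nM. Within the data shown here, compound 3 `O=C(N/N=C/c1ccc(F)cc1Cl)Nc1cc2c(Nc3ccc(F)c(Cl)c3)ncnc2cc1O[C@H]1CCOC1` gives 26100 nM, level with compound 2 within the scatter, and these two values are the only numbers available.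

Compound 4 `COc1ccc(/C=N/NC(=O)Nc2cc3c(Nc4ccc(F)c(Cl)c4)ncnc3cc2O[C@H]2CCOC2)cc1` has not been measured. The change is 4-methoxyphenyl in place of 2-chloro-4-fluorophenyl on a carbon with a double bond to nitrogen.

Among the measured compounds shown here, one measured step bears on this: a 1.2-fold lower number from compound 2 to compound 3 (0.09 log units; within the scatter). It exchanges the group at the same place and is small. For the measured compounds named here, no measured compound carries 4-methoxyphenyl, so the evidence is thin, and the result for compound 1 leaves open that no number is reported at all.

The expected change is a 1.1-fold higher number from compound 3 to compound 4 (0.06 log units; within the scatter), with no step beyond the scatter anticipated. For compound 4 the estimate is 30000 nM, with an expected range of 12000 nM to 65000 nM.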

Compound 4, half-maximal inhibitory concentration: 28800 nM
The estimate for compound 4 lay 1.0-fold (0.02 log units) above the measured number; measured number inside the range.
By their numbers in this assay, from the lowest: compounds 3, 4 and 2 (each within the scatter of the next).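

With compound 4 the group on a carbon with a double bond to nitrogen no longer carries a halogen, and it brings an oxygen and a hydrogen-bond acceptor, yet in this assay the step of a 1.1-fold higher number from compound 3 to compound 4 (0.04 log units; within the scatter) stays small, as does the step of a 1.1-fold lower number from compound 2 to compound 4 (0.05 log units; within the scatter). The three numbered compounds therefore stand level across 3-bromophenyl, 2-chloro-4-fluorophenyl and 4-methoxyphenyl, a pattern that compound 1 does not join, since compound 1 gives "not active" (no number reported) in this assay and provides no number. Nothing shown accounts for this flat result.

As far as these compounds go, it remains open whether any group at this place moves the number beyond the scatter, for example a phenyl bearing an amine or a carboxylic acid, or a longer chain in place of the phenyl. The gap between compound 1 and the numbered compounds also remains unexplained.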